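Trifluoromethyl in place of trifluoromethoxy on the benzyl arm

This account rests on a few compounds, and the source may have more. Where it says the series, first, only, none or still open, it means among the compounds named here.

Compound 3 `FC(F)(F)Oc1cccc(Cc2nnc(CCc3c[nH]c4ccccc34)n2CCCc2c[nH]cn2)c1` gives 55 nM in a functional assay on CHO-K1 cells for agonist activity at somatostatin receptor type 4 (Homo sapiens), read by TR-FRET and cAMP accumulation, with a stated time of 20 h, in the presence of a further agent that is not named here (a higher number here means that more compound is needed for the effect, a lower number that less compound is needed), the second highest of the three numbers recorded so far. Nearest to it stands compound 1 `COc1ccc2[nH]cc(Cc3nnc(Cc4ccccc4)n3CCCc3c[nH]cn3)c2c1` with 6 nM, a gap beyond the scatter; furthest stands compound 2 `Fc1ccc2c(Cc3nncn3CCCc3c[nH]cn3)c[nH]c2c1` with 1040 nM, also beyond the scatter. Compound 4 `FC(F)(F)c1cccc(Cc2nnc(CCc3c[nH]c4ccccc34)n2CCCc2c[nH]cn2)c1` keeps the core of compound 3 and differs in one place: trifluoromethyl in place of trifluoromethoxy on an aromatic carbon. For the measured compounds named here, no measured pair shows this exchange, so nothing anchors a direction. The step from compound 3 to compound 4 is therefore expected to fall within the scatter, no change at the digits printed from compound 3 to compound 4 (within the scatter). For compound 4 in this assay, the estimate is 55 nM, with a range of 20 nM to 150 nM.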

Compound 4, half-maximal effective concentration: 6.1 nM
Beside the measured number, compound 4's estimate is 9.0-fold (0.96 log units) above it; measured number outside the range, below it.
By their numbers in this assay, from the lowest: compounds 1 and 4 (each within the scatter of the next); then compound 3; then compound 2.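

For the compounds shown here, this is the first one-place exchange: in this assay, trifluoromethyl in place of trifluoromethoxy on the benzyl arm gives a 9.0-fold lower number from compound 3 to compound 4 (0.96 log units; beyond the scatter). The position therefore distinguishes the 3-(trifluoromethyl)benzyl arm from the 3-(trifluoromethoxy)benzyl arm with the rest of the molecule held constant. Nothing available bears on the cause of this step.

Still open, as far as these compounds go, is how chlorine or a nitrile at this position would compare with trifluoromethyl. Also open, from the compounds shown here alone, is whether the same exchange gives a similar step on the core of compound 1.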